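A few compounds are considered here, and "the series" means these few. Any claim that something is new, unique, unknown or untested is made for them only; others in the source may bear on it.

Measured so far in a functional assay on A549 cells (Homo sapiens) for cytotoxicity, read by MTT assay, with a stated time of 48 h; on this read-out higher numbers stand for higher solubility and lower numbers for lower solubility:
- compound 1 `O=C(N/N=C/c1ccco1)c1cc(-c2ccccc2)nn1Cc1ccccc1`: 12500 nM
- compound 2 `O=C(N/N=C/c1ccco1)c1cc(-c2ccccc2)nn1Cc1ccc(Cl)nc1`: 50000 nM
- compound 3 `O=C(N/N=C/c1ccco1)c1cc(-c2ccc(Cl)cc2)nn1Cc1ccc(Cl)nc1`: 70000 nM

Compound 1 stands lowest of the three numbers in this assay. Its nearest neighbour is compound 2, reached by a 4.0-fold higher number from compound 1 to compound 2 (0.60 log units; beyond the scatter); compound 3 lies furthest off, and the step of a 1.4-fold higher number from compound 2 to compound 3 (0.15 log units; within the scatter) adds little to that gap.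

Compound 4 `O=C(N/N=C/c1ccccc1O)c1cc(-c2ccccc2)nn1Cc1ccccc1` is the next candidate. It differs from compound 1 by 2-hydroxyphenyl in place of furan-2-yl on a carbon with a double bond to nitrogen. This change sits on the hydrazone carbon, a place that neither measured step touches: the step from compound 1 to compound 2 alters the group on the saturated chain carbon bound to an aromatic nitrogen, and the step from compound 2 to compound 3 alters a substituent on the pendant aromatic ring. Among the measured compounds shown here, no measured pair therefore bears directly on the change to compound 4, and the two steps seen so far in this assay were modest or within the scatter. For this assay the expectation for compound 4 is a step no larger than the scatter, with no firm direction, expressed as a 1.1-fold higher number from compound 1 to compound 4 (0.05 log units; within the scatter). Compound 4 is accordingly estimated at 14000 nM, with a range from 5000 nM to 45000 nM.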

Compound 4, solubility: 44000 nM
Beside the measured number, compound 4's estimate is 3.1-fold (0.50 log units) below it, and the stated range covers the measured number.
By their numbers in this assay, from the lowest: compound 1; then compounds 4, 2 and 3 (each within the scatter of the next).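

In this assay, among the compounds shown here, the carbon with a double bond to nitrogen responds to substitution: 2-hydroxyphenyl in place of furan-2-yl gives a 3.5-fold higher number from compound 1 to compound 4 (0.55 log units; beyond the scatter), the first reading at this position. The step is modest and beyond the scatter, like a 4.0-fold higher number from compound 1 to compound 2 (0.60 log units; beyond the scatter), so two separate places on compound 1 now each show a higher number when changed. The swap alters ring size and hydrogen-bond donor count together, and no measurement at hand says which of these, if either, carries the step.

The compounds shown leave open whether the step belongs to the hydroxy group or to the six-membered aromatic ring, a question that phenyl, 2-methoxyphenyl or 2-aminophenyl on this carbon would help to separate. Also open is whether this change adds to the one on the saturated chain carbon bound to an aromatic nitrogen, since no compound shown carries 2-hydroxyphenyl together with 6-chloropyridin-3-yl.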